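Shortening the Chain by One Carbon

A few compounds are considered here, and "the series" means these few. Any claim that something is new, unique, unknown or untested is made for them only; others in the source may bear on it.

Of the compounds shown here, three sharing one core have been tested in a functional assay on DU-145 cells (Homo sapiens) for cytotoxicity, read by MTT assay, with a stated time of 2 days, tested at 10 uM; on this read-out higher numbers stand for more inhibition at the one concentration tested (going by the name of the read-out) and lower numbers for less inhibition. Compound 1 `CCCCNc1nc(NCc2ccco2)c2ccccc2n1` gives 89.9%. Compound 2 `CCCCCNc1nc(NCc2ccco2)c2cc(F)ccc2n1` gives 83.6%, and compound 3 `Clc1cccc(N2CCN(CCCNc3nc(NCc4ccco4)c4ccccc4n3)CC2)c1Cl` gives 93.2%. Compound 2 sits at the lower edge of these three numbers, yet both gaps to the other two lie within the usual scatter, so the three cannot be told apart on this read-out. Compound 4 `CCCCNc1nc(NCc2ccco2)c2cc(F)ccc2n1` is the next compound to be measured in this assay. Its difference from compound 2 is hydrogen in place of methyl on a saturated chain carbon, four bonds along the chain from a nitrogen on an aromatic ring. Within the data shown here, no step between two measured compounds of this kind exists in the data, so no step beyond the scatter is expected. Compound 4 is expected to give 87%, between 78% and 94%. The expected step of a number 3.4 percentage points higher from compound 2 to compound 4 (within the scatter) amounts to nothing beyond the scatter.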

Compound 4, a percentage reported as inhibition, at one concentration (the size of the read-out at that concentration, not a potency): 75.4%
For compound 4 the middle estimate is 11.6 percentage points above the measured one; measured number outside the range, below it.
By their numbers in this assay, from the lowest: compounds 4, 2, 1 and 3 (each within the scatter of the next, the first and the last beyond it).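

Hydrogen in place of methyl on this saturated chain carbon gives a number 8.2 percentage points lower from compound 2 to compound 4 (within the scatter), so this first step at the position cannot be told from the scatter. Fluoro in place of hydrogen on an aromatic carbon gives a number 14.5 percentage points lower from compound 1 to compound 4 (beyond the scatter), a modest step and the first here that stands clear of the scatter. No measured evidence bears on why this step occurs. Going by these compounds, what a hydroxyl group on this chain carbon would do in this assay remains open, and so does what methoxy in place of fluoro on the aromatic carbon would do.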